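The compounds below may be only part of what the source reports. "The series", "measured", "known", "first", "only" and "open" are said of these compounds alone.

Working notes on the series. Compound 1 `COc1ccc(C(=O)c2cc(OC)c(OC)c(OC)c2)cc1N` is the shared core bearing a free amine, and in a functional assay on COLO 205 cells (Homo sapiens) for cytotoxicity, read by MTT assay, with a stated time of 72 h (a higher number here means a weaker inhibitor, a lower number a stronger inhibitor), compound 1 gives 200 nM. Going by the values given here, compound 2 `COc1ccc(C(=O)c2cc(OC)c(OC)c(OC)c2)cc1NC(=O)/C=C/c1ccc(OC)c(OC)c1` carries on that amine an unsaturated amide ending in 3,4-dimethoxyphenyl; in this assay compound 2 gives 8200 nM, the highest of the two numbers so far, the gap to compound 1 lying beyond the scatter. Compound 3 `C#CCOc1cccc(/C=C/C(=O)Nc2cc(C(=O)c3cc(OC)c(OC)c(OC)c3)ccc2OC)c1` remains to be measured. The change from compound 2 to compound 3 is 3-(propargyloxy)phenyl in place of 3,4-dimethoxyphenyl on a double-bonded chain carbon bound to a double-bonded chain carbon. Among the compounds with values here, no measured pair covers this change, and compound 2 is the only amide-bearing reference. The expected step in this assay is therefore taken as a 1.0-fold lower number from compound 2 to compound 3 (0.01 log units; within the scatter), small and not clearly beyond the scatter in either direction. Compound 3 is accordingly estimated at 8000 nM, with a range from 2500 nM to 25000 nM.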

Compound 3, half-maximal inhibitory concentration: 13400 nM
The estimate for compound 3 lay 1.7-fold (0.22 log units) below the measured number; measured number inside the range.
By their numbers in this assay, from the lowest: compound 1; then compounds 2 and 3 (each within the scatter of the next).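

In this assay, 3-(propargyloxy)phenyl in place of 3,4-dimethoxyphenyl on a double-bonded chain carbon bound to a double-bonded chain carbon gives a 1.6-fold higher number from compound 2 to compound 3 (0.21 log units; within the scatter), the first step read at this end of the amide. At this position, then, the exchange of these two groups, which brings in a triple bond outside aromatic rings, does not separate compound 2 from compound 3. Nothing at hand bears on why the two read alike.

Open, on these data alone, is whether an amine or a carboxylic acid in place of 3-(propargyloxy)phenyl on this chain would give a number separated from both compounds beyond the scatter. Also open, as far as these compounds go, is whether a longer chain or a saturated chain carrying the same ring would read any differently from compound 2.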